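A fluorine for a methyl on the triazole aryl

The compounds below may be only part of what the source reports. "The series", "measured", "known", "first", "only" and "open" are said of these compounds alone.

Going by the values given here, only two compounds have numbers so far in a functional assay on A549 cells (Homo sapiens) for antiproliferative activity, read by MTT assay, with a stated time of 24 h; on this read-out lower numbers stand for stronger inhibition and higher numbers for weaker inhibition. Among the compounds with values here, compound 2 `Cc1ccc(-n2cc(-c3ccc(NS(=O)(=O)c4c[nH]c(=O)[nH]c4=O)cc3)nn2)cc1` gives 5560 nM in this assay, and its single neighbour, compound 1 `O=c1[nH]cc(S(=O)(=O)Nc2ccc(-c3cn(-c4ccccc4)nn3)cc2)c(=O)[nH]1`, gives 7170 nM, so the two stand within the scatter of each other. Within the data shown here, the one step between them, a 1.3-fold lower number from compound 1 to compound 2 (0.11 log units; within the scatter), is a methyl in place of hydrogen on an aromatic carbon of the phenyl on the triazole nitrogen.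

Compound 3 `O=c1[nH]cc(S(=O)(=O)Nc2ccc(-c3cn(-c4cccc(F)c4)nn3)cc2)c(=O)[nH]1` alters that same phenyl once more: 3-fluorophenyl in place of 4-methylphenyl on an aromatic nitrogen. Among the measured compounds shown here, no measured step swaps one substituted phenyl for another on this nitrogen, so the only step that bears on the change is a 1.3-fold lower number from compound 1 to compound 2 (0.11 log units; within the scatter), which touched the same ring and stayed within the scatter. On that basis a further small change at this position is expected to move the number by no more than the scatter. The expected step is a 1.1-fold higher number from compound 2 to compound 3 (0.03 log units; within the scatter). In this assay compound 3 is therefore estimated at 6000 nM, with a range from 2500 nM to 14000 nM.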

Compound 3, half-maximal inhibitory concentration: 9980 nM
Compound 3: middle estimate off by 1.7-fold (0.22 log units), on the low side; the measured number falls inside the stated range.
By their numbers in this assay, from the lowest: compounds 2, 1 and 3 (each within the scatter of the next).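

In this assay, going by these compounds alone, the step of a 1.8-fold higher number from compound 2 to compound 3 (0.25 log units; within the scatter) is the first to exchange one substituted phenyl for another on this aromatic nitrogen, and it lies within the scatter even though the substituent and its place on the ring differ together. Fluoro in place of hydrogen, a 1.4-fold higher number from compound 1 to compound 3 (0.14 log units; within the scatter), is also within the scatter, as is the methyl step a 1.3-fold lower number from compound 1 to compound 2 (0.11 log units; within the scatter), so neither 4-methylphenyl nor 3-fluorophenyl separates from the unsubstituted phenyl of compound 1, and all three compounds stay within the scatter of one another. No measurement offered here bears on the result, and the values alone give no explanation for it.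

The compounds shown leave open whether an amine or a carboxylic acid on this phenyl, or a longer chain in place of the methyl, would move the number beyond the scatter. They also leave the substituent and its ring place unseparated: 4-fluorophenyl, set against both 4-methylphenyl and 3-fluorophenyl, would vary one of them at a time.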